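Cyclobutyl ether on the shared core: expected oral bioavailability

A few compounds are considered here, and "the series" means these few. Any claim that something is new, unique, unknown or untested is made for them only; others in the source may bear on it.

Among the compounds with values here, compound 3 `C[C@@H](Cn1c(=O)[nH]/c(=N\c2ccc(Oc3ccsn3)cc2)n(Cc2ccc(Cl)cc2)c1=O)C(=O)O` gives the highest number of the three measured members in an ADME assay on the whole organism (Rattus norvegicus) for pharmacokinetics, using cassette dosing, at a dose of 1 mg/kg by the oral route (a lower number here means that a smaller share of the oral dose reaches the circulation, a higher number that a larger share of the oral dose reaches the circulation), at 87.6%. Compound 2 `C[C@@H](Cn1c(=O)[nH]/c(=N\c2ccc(Oc3cncc(F)c3)cc2)n(Cc2ccc(Cl)cc2)c1=O)C(=O)O` follows with 74.3%, and compound 1 `C[C@@H](Cn1c(=O)[nH]/c(=N\c2ccc(Oc3ccccn3)cc2)n(Cc2ccc(Cl)cc2)c1=O)C(=O)O` gives 52.8%. The measured steps are a number 21.5 percentage points higher from compound 1 to compound 2 (beyond the scatter), a number 34.8 percentage points higher from compound 1 to compound 3 (beyond the scatter) and a number 13.3 percentage points higher from compound 2 to compound 3 (beyond the scatter); each swaps one aromatic heterocycle for another on the oxygen on the aromatic ring.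

Compound 4 `C[C@@H](Cn1c(=O)[nH]/c(=N\c2ccc(OC3CCC3)cc2)n(Cc2ccc(Cl)cc2)c1=O)C(=O)O` differs from compound 3 in one place: cyclobutyl in place of 1,2-thiazol-3-yl on an oxygen on an aromatic ring. Within the data shown here, no measured step introduces a non-aromatic ring at this position, so none bears directly on the change; the measured range runs from compound 1 to compound 3. For compound 4 a step of a number 17.6 percentage points lower from compound 3 to compound 4 (beyond the scatter) is expected, a modest decrease within the span already seen. Compound 4 is estimated at 70%, between 45% and 95%.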

Compound 4, oral bioavailability: 54.3%
Beside the measured number, compound 4's estimate is 15.7 percentage points above it; measured number inside the range.
By their numbers in this assay, from the lowest: compounds 1 and 4 (each within the scatter of the next); then compound 2; then compound 3.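

In this assay, cyclobutyl on this oxygen loses much of what the 1,2-thiazol-3-yl group holds, with a number 33.3 percentage points lower from compound 3 to compound 4 (beyond the scatter), and it also stays under the 5-fluoropyridin-3-yl group, with a number 20 percentage points lower from compound 2 to compound 4 (beyond the scatter). Against pyridin-2-yl it does not separate, with a number 1.5 percentage points higher from compound 1 to compound 4 (within the scatter), so compound 1 goes against any reading that an aromatic ring on this oxygen alone gives the higher numbers. Nothing measured on hand accounts for these steps. On these data alone, whether a cyclohexyl ring, an open isopropyl chain or a cyclobutyl ring carrying an amine would come nearer to compound 3 stays open.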